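The source may report more compounds than this note shows. Statements on the series, on what has been measured and on what is new or still open speak of the compounds shown alone.

Measured compounds:
Compound 1, `CCOC(=O)c1c(C)nc(-c2ccccc2C#N)n1OC` — 14900 nM
Compound 2, `C=CCOn1c(-c2cccc(C#N)c2)nc(C)c1C(=O)OCC` — 5860 nM

In a functional assay on a cell-free system (plasma, Oryctolagus cuniculus) for inhibition, with stated times of 5 min, 1 min and 6 min (a lower number here means a stronger inhibitor, a higher number a weaker inhibitor), compound 2 holds the lower of the two numbers shown; compound 1 gives 14900 nM, a gap beyond the usual scatter, though the two structures differ in more than one respect, so no single change can be read from that gap. Compound 3, `CCOC(=O)c1c(C)nc(-c2cccc(C#N)c2)n1OCc1ccccc1F`, has not yet been measured in this assay. It is reached from compound 2 by one change: 2-fluorophenyl in place of vinyl on a saturated chain carbon bound to an oxygen on an aromatic ring. For the measured compounds named here, with no measured pair of this kind to lean on, the size of the step remains open. A modest move toward a stronger inhibitor, beyond the scatter, is expected, the step of a 2.0-fold lower number from compound 2 to compound 3 (0.29 log units; within the scatter) being the estimate. Compound 3 is thus expected to give 3000 nM in this assay, with a range from 800 nM to 12000 nM.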

Compound 3, half-maximal inhibitory concentration: 8990 nM
Compound 3: the middle estimate sits 3.0-fold (0.48 log units) below what was measured; measured number inside the range.
By their numbers in this assay, from the lowest: compounds 2, 3 and 1 (each within the scatter of the next, the first and the last beyond it).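

In this assay the position on the saturated chain carbon bound to the oxygen accepts a large change without a readable effect: a 1.5-fold higher number from compound 2 to compound 3 (0.19 log units; within the scatter). The six-membered aromatic ring of 2-fluorophenyl enters where vinyl and its double bond leave, and the numbers of the two compounds stay within the scatter of each other, so this single pair gives no sign that the choice between allyl and 2-fluorobenzyl matters here. Nothing measured on these compounds offers an explanation for this outcome.

As far as these compounds go, whether plain benzyl, a longer chain or an amine on this oxygen would move the number beyond the scatter stays open. From the compounds shown here alone, it is also open whether the same change would read alike with the nitrile placed as in compound 1.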